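A few compounds are considered here, and "the series" means these few. Any claim that something is new, unique, unknown or untested is made for them only; others in the source may bear on it.

Compound 1 `O=C(NO)c1ccc(NCc2nc(-c3ccc(Cl)cc3)nn2-c2ccccc2)cc1` was tested in an assay on Sf9 cells for inhibition of protein deacetylase HDAC6 (Homo sapiens), read by fluorescence, with a stated time of 40 min, tested at 100 nM (on this read-out lower numbers stand for less inhibition and higher numbers for more inhibition at the one concentration tested (going by the name of the read-out)), and gives 67.2%. Among the three compounds measured so far, this is the highest number. Compound 2 `O=C(NO)c1ccc(NCc2nc(-c3ccccc3)nn2-c2ccc(Br)cc2)cc1` gives 65.9% in this assay, a number that sits within the usual scatter of that of compound 1, so the two cannot be told apart. Compound 3 `NNC(=O)c1ccc(NCc2nc(-c3ccccc3)nn2-c2ccccc2)cc1` gives 10% in this assay, a number far lower than that of compound 1 and well beyond the scatter.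

Compound 4 `Cc1cccc(-c2nc(CNc3ccc(C(=O)NO)cc3)n(-c3ccccc3)n2)c1` has not yet been measured. It differs from compound 1 in one place: 3-methylphenyl in place of 4-chlorophenyl on an aromatic carbon. Going by the values given here, no step between measured compounds matches this kind of change, so the data give no direct guide to its size. Among the compounds with values here, the only hint is that compound 1 and compound 2, which differ in their aryl groups, give numbers within the scatter of each other. The expected step is therefore small, a number 5.2 percentage points lower from compound 1 to compound 4 (within the scatter), with no change beyond the scatter in either direction. Compound 4 is estimated at 62% in this assay, with a range from 42% to 78%.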

Compound 4, a percentage reported as inhibition, at one concentration (the size of the read-out at that concentration, not a potency): 64.1%
Compound 4: middle estimate off by 2.1 percentage points, on the low side, and the stated range covers the measured number.
By their numbers in this assay, from the lowest: compound 3; then compounds 4, 2 and 1 (each within the scatter of the next).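

Going by these compounds alone, at this position on the five-membered aromatic ring with 3 nitrogen, 3-methylphenyl in place of 4-chlorophenyl gives, in this assay, a number 3.1 percentage points lower from compound 1 to compound 4 (within the scatter) and is the first measured step here. For this one pair, the chlorine can give way to a methyl group, on a different carbon of the phenyl ring, with no step beyond the scatter, so the single-place comparison shows that this exchange leaves the read-out at the one tested concentration unresolved from that of compound 1. No measurement shown here speaks to why the two compounds cannot be told apart.

The compounds shown leave open whether this position would accept a phenyl ring carrying an amine or a carboxylic acid. They also leave open what a longer chain in place of the aryl group would do to the number.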